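Shortening the hydroxyl-bearing substituent on the shared core

The source may hold more compounds than are shown below. What is called first, only, known or untested is meant among the compounds shown, and "the series" means these compounds.

Compound 3 `OC1CCC(Nc2nc(-c3ccccc3)nc3c2nnn3Cc2ccccc2Cl)CC1` stands second highest of the three compounds measured in an assay on isolated protein for binding affinity to adenosine receptor A1 (Bos taurus) (a lower number here means a stronger inhibitor, a higher number a weaker inhibitor), where compound 3 gives 3100000 nM. Its nearest neighbour, compound 2 `OC1CCC(Nc2nc(-c3ccccc3)nc3c2nnn3Cc2ccccc2)CC1`, gives 2700000 nM, and the step of a 1.1-fold higher number from compound 2 to compound 3 (0.06 log units; within the scatter) lies within the scatter. Compound 1 `OCCCNc1nc(-c2ccccc2)nc2c1nnn2Cc1ccccc1Cl` gives 33000000 nM, and the step of an 11-fold lower number from compound 1 to compound 3 (1.03 log units; beyond the scatter) is large. Compound 4 `CC(O)CNc1nc(-c2ccccc2)nc2c1nnn2Cc1ccccc1Cl` differs from compound 3 by 2-hydroxypropyl in place of 4-hydroxycyclohexyl on a nitrogen on an aromatic ring. Because an 11-fold lower number from compound 1 to compound 3 (1.03 log units; beyond the scatter) exchanged a short hydroxyalkyl chain for the 4-hydroxycyclohexyl ring, the reverse exchange here is expected to raise the number, though 2-hydroxypropyl is not identical to 3-hydroxypropyl. The expected step in this assay is a 6.5-fold higher number from compound 3 to compound 4 (0.81 log units; beyond the scatter). Compound 4 is therefore estimated at 20000000 nM, within 5000000 nM to 60000000 nM.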

Compound 4, inhibition constant: 32000000 nM
Compound 4: the middle estimate sits 1.6-fold (0.20 log units) below what was measured; the range from low to high includes it.
By their numbers in this assay, from the lowest: compounds 2 and 3 (each within the scatter of the next); then compounds 4 and 1 (each within the scatter of the next).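

In this assay, the 2-hydroxypropyl chain on this nitrogen in place of 4-hydroxycyclohexyl gives a 10-fold higher number from compound 3 to compound 4 (1.01 log units; beyond the scatter) and so shows that the large gap to the ring holds for a second open chain. Where the hydroxyl sits on the chain makes no difference beyond the scatter, with a 1.0-fold lower number from compound 1 to compound 4 (0.01 log units; within the scatter) as the reading. No evidence is available to explain either step. Still open, going by these compounds, is whether the hydroxyl matters at all, and how plain cyclohexyl, an amine in place of the hydroxyl or a longer chain would compare.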